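The source may report more compounds than this note shows. Statements on the series, on what has been measured and on what is new or still open speak of the compounds shown alone.

Of the compounds shown here, three have numbers so far in a physicochemical assay for lipophilicity, read by HPLC, measured as chromatographic lipophilicity, at pH 7.4; a lower number here means a more polar compound, a higher number a more lipophilic compound. Compound 1 (`Cc1ccc(C2CC=NN2C(=O)C(C)(C)C)cc1`) gives 6.4 on this scale, and compound 3 (`O=C(C1CCN(c2ccncn2)CC1)N1N=CC[C@H]1c1ccccc1`) gives 3.2 on the same scale. Compound 2 (`CC(=O)N1CCC(C(=O)N2N=CCC2c2ccccc2)CC1`) gives 2.5 and is the lowest of the three, with each of the other two higher by more than the usual scatter of repeated measurements.

Compound 4 (`O=C(c1cccnc1)N1CCC(C(=O)N2N=CCC2c2ccccc2)CC1`) has no number yet. It is compound 2 with a single change, pyridin-3-yl in place of methyl on a carbonyl carbon. The same difference can be read as acetyl giving way to (pyridin-3-yl)carbonyl.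

Going by the values given here, none of the measured compounds differ from each other in one place only, so no measured pair shows what a change like this does, and any forecast is a judgement rather than a reading from precedent. The expected level is guided by compound 3 at 3.2 rather than by compound 1 at 6.4 in this assay here. A rise of moderate size, beyond the scatter, is expected, with a number 0.70 log units higher from compound 2 to compound 4 (beyond the scatter) as the estimated step. Compound 4 is estimated at 3.2 with an expected range from 2.7 to 3.8 on this scale.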

Compound 4, distribution coefficient: 2.6
Compound 4: middle estimate off by 0.60 log units, on the high side; the measured number lies below the stated range.
By their numbers in this assay, from the lowest: compounds 2 and 4 (each within the scatter of the next); then compound 3; then compound 1.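

In this assay, putting pyridin-3-yl in place of methyl on a carbonyl carbon, so that acetyl gives way to (pyridin-3-yl)carbonyl, gives a number 0.10 log units higher from compound 2 to compound 4 (within the scatter). Going by these compounds alone, this is the first measured pair that differs in one place only, and it shows that at this position a group of 1 heavy atom can be exchanged for one of 6 heavy atoms, including a six-membered aromatic ring with 1 hetero atom, without the two numbers separating beyond the scatter of repeated measurements. Nothing available bears on why the numbers of this pair lie so close together.

A single pair cannot show whether the same exchange would read the same way on another core, so this result holds for this one position in this one series. It also leaves open what a plain phenyl ring would give on the same carbonyl carbon, which would set the ring apart from its nitrogen, and whether a carboxylic acid, an amine or a longer alkyl chain there would move the number beyond the scatter.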